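The source may report more compounds than this note shows. Statements on the series, on what has been measured and on what is new or still open speak of the compounds shown alone.

Within the data shown here, compound 1, whose structure is `CO/N=C1\C(=O)N(CCCN2CCN(c3cc4c(cc3F)c(=O)c(C(=O)O)cn4C3CC3)CC2)c2ccccc21`, sits at the lower end of the two numbers so far recorded: in an ADME assay on Vero cells (Chlorocebus sabaeus) for cytotoxicity, read by MTT assay, with a stated time of 72 h (on this read-out higher numbers stand for lower toxicity in this test and lower numbers for higher toxicity in this test), compound 1 gives 32 ug/mL, the lowest of the pair. Its closest neighbour is compound 2, with structure `CCO/N=C1\C(=O)N(CCCN2CCN(c3cc4c(cc3F)c(=O)c(C(=O)O)cn4C3CC3)CC2)c2ccccc21`, which in this assay gives 64 ug/mL; the step of a 2.0-fold higher number from compound 1 to compound 2 (0.30 log units; within the scatter) lies within the scatter, so the two compounds are not separated by this test.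

Compound 3, with structure `CO/N=C1\C(=O)N(CCCN2CCN(c3cc4c(cc3F)c(=O)c(C(=O)O)cn4C3CC3)CC2)c2ccc(C)cc21`, is the next compound in line. It differs from compound 1 by methyl in place of hydrogen on an aromatic carbon. Among the measured compounds shown here, the single measured step, a 2.0-fold higher number from compound 1 to compound 2 (0.30 log units; within the scatter), concerns a change on the alkoxy chain rather than on an aromatic carbon of the fused ring, so it bears on the new change only indirectly; it shows that a small added carbon left the read-out of this assay within the scatter. On that basis the expected step for compound 3 is no change at the digits printed from compound 1 to compound 3 (within the scatter), that is, no shift beyond the scatter in either direction. Compound 3 is therefore estimated at 32 ug/mL, with a range from 16 ug/mL to 64 ug/mL.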

Compound 3, half-maximal cytotoxic concentration: 256 ug/mL
Compound 3: middle estimate off by 8.0-fold (0.90 log units), on the low side; measured number above the stated range.
By their numbers in this assay, from the lowest: compounds 1 and 2 (each within the scatter of the next); then compound 3.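

Methyl in place of hydrogen on an aromatic carbon of the six-membered aromatic ring of carbon only gives an 8.0-fold higher number from compound 1 to compound 3 (0.90 log units; beyond the scatter) in this assay and so marks this carbon as a place where one added heavy atom moves the number beyond the scatter, in the direction of lower toxicity in this test. The earlier step, which also put a methyl in place of a hydrogen but on the saturated chain carbon bound to oxygen, was a 2.0-fold higher number from compound 1 to compound 2 (0.30 log units; within the scatter) and did not separate its two compounds, so in these two steps the outcome depends on where the methyl stands. Nothing at hand gives a reason for the size of the new step.

The compounds shown leave open whether this step belongs to methyl in particular or whether a chlorine atom, a methoxy group or an amine on the same aromatic carbon would raise the number as well. They also leave open whether a longer chain such as ethyl there would carry the number further, since this carbon is represented by a single change.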